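The source may hold more compounds than are shown below. What is called first, only, known or untested is meant among the compounds shown, and "the series" means these compounds.

Measured compounds: compound 1 `CC(C)C(NC(=O)c1ccc(C#Cc2ccccc2)cc1)C(=O)NO`, compound 2 `O=C(NC1(C(=O)NO)CCCCC1)c1ccc(C#Cc2ccccc2)cc1`, compound 3 `NC(=O)C[C@H](NC(=O)c1ccc(C#Cc2ccccc2)cc1)C(=O)NO`.

In a physicochemical assay for lipophilicity (a higher number here means a more lipophilic compound, a lower number a more polar compound), compound 1 returns only a limit, > 3. Compound 2 likewise returns only a limit in this assay, > 3. Within the data shown here, compound 3 is the one compound with a number here, giving 1 in this assay, so it is the polar end of the three, the other two sitting at the limit of > 3 in this assay, at which 2 of the 3 values shown sit. Compound 4 `CS(=O)(=O)C[C@H](NC(=O)c1ccc(C#Cc2ccccc2)cc1)C(=O)NO` is not yet measured. It differs from compound 3 in one place: methylsulfonyl in place of carbamoyl on a saturated chain carbon, two bonds along the chain from an amide-type nitrogen and a carbonyl carbon. Among the measured compounds shown here, no measured pair isolates this change, so the expectation rests on the structures alone. The step is expected to be small and upward, at the edge of the scatter, a number 0.30 log units higher from compound 3 to compound 4 (within the scatter). Compound 4 is therefore estimated at 1.3, within 0.6 to 2.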

Compound 4, distribution coefficient: 2
The estimate for compound 4 lay 0.70 log units below the measured number, and the stated range covers the measured number.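

Among these compounds, this is the first measured step at this position, the saturated chain carbon two bonds along the chain from an amide-type nitrogen and a carbonyl carbon. In this assay, methylsulfonyl in place of carbamoyl gives a number 1.00 log units higher from compound 3 to compound 4 (beyond the scatter), so the read-out responds to the group at this place, with no net charge on either group.

On these data alone, how a carboxylic acid, an amine or a longer chain on this carbon would read in this assay stays open. Compound 1 and compound 2 each give only a limit and not a number: the limit of > 3 in this assay, at which 2 of the 4 values shown sit.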